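The compounds below may be only part of what the source reports. "The series", "measured", "known", "first", "only" and "open" are said of these compounds alone.

The measured compounds, in a functional assay on HL-60 cells (Homo sapiens) for antiproliferative activity, with a stated time of 24 h; on this read-out higher numbers stand for weaker inhibition and lower numbers for stronger inhibition:
compound 1, `NC(=O)c1c(NC(=O)c2ccccc2F)sc2c1CCN(C(=S)Nc1ccccc1Cl)C2`, gives 12500 nM
compound 2, `NC(=O)c1c(NC(=O)c2ccccc2Br)sc2c1CCN(C(=S)Nc1ccccc1Cl)C2`, gives 14600 nM
compound 3, `NC(=O)c1c(NC(=O)c2ccccc2C(F)(F)F)sc2c1CCN(C(=S)Nc1ccccc1Cl)C2`, gives 17600 nM

Compound 3 has the highest of the three numbers, but the steps that lead to it, a 1.4-fold higher number from compound 1 to compound 3 (0.15 log units; within the scatter) and a 1.2-fold higher number from compound 2 to compound 3 (0.08 log units; within the scatter), both lie within the scatter, as does a 1.2-fold higher number from compound 1 to compound 2 (0.07 log units; within the scatter); the three compounds cannot be told apart on these measurements.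

Compound 4, `Cc1ccc(C(=O)Nc2sc3c(c2C(N)=O)CCN(C(=S)Nc2ccccc2Cl)C3)cc1`, differs from compound 3 by 4-methylphenyl in place of 2-(trifluoromethyl)phenyl on a carbonyl carbon. All three measured steps exchange the ring on this carbonyl carbon, and none of them moves the number beyond the scatter. For the measured compounds named here, no measured step brings in a 4-methylphenyl, so no step bears directly on this change; the closest evidence is that three different rings on the carbonyl carbon gave indistinguishable numbers. The step expected from this change, a 1.2-fold lower number from compound 3 to compound 4 (0.07 log units; within the scatter), is therefore none beyond the scatter. Compound 4 is estimated at 15000 nM, with a range from 5000 nM to 45000 nM.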

Compound 4, half-maximal inhibitory concentration: 8430 nM
Beside the measured number, compound 4's estimate is 1.8-fold (0.25 log units) above it, and the stated range covers the measured number.
By their numbers in this assay, from the lowest: compounds 4, 1, 2 and 3 (each within the scatter of the next, the first and the last beyond it).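

In this assay, for the compounds shown here, the ring on the carbonyl carbon gives, for the first time, a step beyond the scatter, a 2.1-fold lower number from compound 3 to compound 4 (0.32 log units; beyond the scatter), so this position is not wholly indifferent to the ring it carries, although the step is modest. The 4-methylphenyl ring separates only from 2-(trifluoromethyl)phenyl, as the other two steps, a 1.7-fold lower number from compound 2 to compound 4 (0.24 log units; within the scatter) and a 1.5-fold lower number from compound 1 to compound 4 (0.17 log units; within the scatter), stay within the scatter. Nothing shown offers an explanation for the step from compound 3 to compound 4.

The 4-methylphenyl ring differs from each of the other rings both in its group and in where that group sits, so the compounds leave open which of the two goes with the step. From the compounds shown here alone, how a 2-methylphenyl or a 4-methoxyphenyl ring would read at this position also remains open.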